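The source may report more compounds than this note shows. Statements on the series, on what has been measured and on what is new or still open speak of the compounds shown alone.

Measured compounds:

- Compound 1, `COc1cc2cc(C#N)ccc2cc1Oc1ccnc(Nc2ccc(C#N)cc2)n1`: in an ADME assay on MT4 cells (Homo sapiens) for cytotoxicity, read by MTT assay, with a stated time of 4 days (a higher number here means that more compound is tolerated, a lower number that less compound is tolerated), compound 1 gives > 318000 nM, a limit of the assay and not a number.
- Compound 2, `Cc1cnc(Nc2ccc(C#N)cc2)nc1Oc1ccc2cc(C#N)ccc2c1`: in this assay compound 2 gives > 331000 nM, again a limit.
- Compound 3, `Cc1cc(Oc2ccc3cc(C#N)ccc3c2)nc(Nc2ccc(C#N)cc2)n1`: in this assay compound 3 gives > 331000 nM, also a limit.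

No value here is a number; every compound shown has stayed tolerated up to the top of the tested range. Compound 3 stands at the limit of > 331000 nM in this assay, at which 2 of the 3 values shown sit, the same limit as compound 2, while compound 1 sits at the limit of > 318000 nM in this assay, at which 1 of the 3 values shown sits. Nothing among these three can be ordered, and no measured step between them exists.

Compound 4, `N#Cc1ccc(Nc2nccc(Oc3ccc4cc(C#N)ccc4c3)n2)cc1`, differs from compound 3 in one place: hydrogen in place of methyl on an aromatic carbon. Since every compound shown has been tolerated to the limit, no step beyond the scatter is expected for this change in this assay, in either direction; the expected step from compound 3 to compound 4 is a number no higher from compound 3 to compound 4 (the limit leaves the size open). For compound 4 the expected value in this assay is 330000 nM, with a range from 120000 nM to 400000 nM, and most probably the assay will again report only a limit.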

Compound 4, half-maximal cytotoxic concentration: > 68800 nM
Compound 4: only a limit was reported (the forecaster's own chance of this, stated with the estimate: 85%); the middle value lies beyond the limit too.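

In this assay compound 4 gives > 68800 nM, a limit and not a number. Among these compounds, no step from compound 1, compound 2 or compound 3 to compound 4 can be read. The compounds shown leave open where the actual cytotoxic concentration of any of the four lies.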